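This account rests on a few compounds, and the source may have more. Where it says the series, first, only, none or still open, it means among the compounds named here.

Compound 1, `O=C(O)CNc1ccc2ccc(C(=O)c3ccc(F)c(O)c3)nc2c1`: > 200000 nM, a limit of the assay.
Compound 2, `COc1cc(C(=O)c2ccc3ccccc3n2)ccc1F`: 100000 nM.

Within the data shown here, in a physicochemical assay for solubility, in phosphate buffer, with a stated time of 24 h, at pH 7.4, tested at 200 uM (a higher number here means a more soluble compound, a lower number a less soluble compound), compound 2 gives 100000 nM, and this is the only plain number among the two measured compounds. For compound 1 the assay reports > 200000 nM, which is a limit of the assay and not a number. The measured set therefore contains (the limit of > 200000 nM in this assay, at which 1 of the 2 values shown sits), so compound 2 stands alone as the reference point with a definite value.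

Compound 3, `O=C(c1ccc(F)c(O)c1)c1ccc2ccccc2n1`, has not yet been measured in this assay. It differs from compound 2 in a single place: hydrogen in place of methyl on an oxygen on an aromatic ring. Among the measured compounds shown here, no pair of measured compounds differs by exactly this change, so there is no measured step to lean on, and the expectation rests on the structural change alone.

Removing the methyl from the oxygen is expected to shift solubility in this assay only modestly, upward if at all, by about a 1.4-fold higher number from compound 2 to compound 3 (0.15 log units; within the scatter). Compound 3 is accordingly estimated at 140000 nM, with a likely range from 60000 nM to 250000 nM.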

Compound 3, solubility: > 200000 nM
Compound 3: no number, only a limit (the forecaster's own chance of this, stated with the estimate: 30%); middle value at least 1.4-fold (0.15 log units) from the limit.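

In this assay, among these compounds, replacing methoxy with hydroxy on the aromatic ring gives an at least 2.0-fold higher number from compound 2 to compound 3 (0.30 log units; that floor lies within the scatter), the first measured step at this position. Compound 3 gives > 200000 nM, which is a limit of the assay and not a number. The step therefore fixes only a floor, and its true size stays hidden since the reading has reached the end of what the assay reports: the limit of > 200000 nM in this assay, at which 2 of the 3 values shown sit.

On these data alone, the step between compound 1 and compound 3 cannot be read, with both values being limits, so these two compounds cannot be put in order and the effect of the (carboxymethyl)amino group on the shared core remains unknown. Also open, as far as these compounds go, is how a longer chain, such as ethyl, or a chain ending in an amine or a carboxylic acid would read on this same oxygen, and whether any such compound would give a plain number rather than a limit.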